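Methoxy removal on the amine-bearing ring: cytotoxicity notes

This account rests on a few compounds, and the source may have more. Where it says the series, first, only, none or still open, it means among the compounds named here.

Compound 1 `O=C1C(Nc2ccc(-c3ccccc3)cc2)=CC(=O)c2ncncc21` is the parent of this set. In a functional assay on PANC-1 cells (Homo sapiens) for cytotoxicity, read by MTT assay, with a stated time of 72 h (on this read-out lower numbers stand for stronger inhibition and higher numbers for weaker inhibition), compound 1 gives 400 nM. Compound 2 `COc1ccc(-c2ccc(NC3=CC(=O)c4ncncc4C3=O)cc2)cc1` differs from compound 1 only by hydrogen in place of methoxy on an aromatic carbon; in this assay compound 2 gives 2300 nM, and the step of a 5.8-fold lower number from compound 2 to compound 1 (0.76 log units; beyond the scatter) is modest. Compound 3 `COc1cc(NC2=CC(=O)c3ncncc3C2=O)cc(OC)c1OC` carries three methoxy groups on the ring attached to the amine nitrogen; in this assay compound 3 gives 800 nM. The difference between the cores of compound 3 and compound 2 is not broken down here; compound 3 stands at 800 nM and compound 2 at 2300 nM.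

Compound 4 `COc1ccc(NC2=CC(=O)c3ncncc3C2=O)cc1OC` arises from compound 3 by hydrogen in place of methoxy on an aromatic carbon. Within the data shown here, this is the same kind of change as the one between compound 2 and compound 1, not the same: there the leaving methoxy sat para to a large group, here it sits ortho to a methoxy group, meta to a large group and meta to a methoxy group. A step of a 1.6-fold lower number from compound 3 to compound 4 (0.20 log units; within the scatter) is expected in this assay. The expectation rests on a 5.8-fold lower number from compound 2 to compound 1 (0.76 log units; beyond the scatter); the surroundings of the place are not the same, so the full size is not assumed. Compound 4 is estimated at 500 nM in this assay, between 150 nM and 1600 nM.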

Compound 4, half-maximal inhibitory concentration: 900 nM
Beside the measured number, compound 4's estimate is 1.8-fold (0.26 log units) below it; measured number inside the range.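

Hydrogen in place of methoxy on an aromatic carbon does not act as a fixed step in this series: in this assay the new pair gives a 1.1-fold higher number from compound 3 to compound 4 (0.05 log units; within the scatter), so compound 3 and compound 4 cannot be told apart on this read-out. Set beside the earlier pair, the same replacement gives clearly different results on the two cores: the same change on two cores in this assay, a 5.8-fold lower number (0.76 log units; beyond the scatter) from compound 2 to compound 1 and a 1.1-fold higher number (0.05 log units; within the scatter) from compound 3 to compound 4, 6.5-fold (0.81 log units) apart, beyond the scatter of two such steps. This shows that the size of the step on one core cannot be carried over to another here, but it does not show which difference between the two cores or the two places accounts for the gap, and two pairs give no general rule.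

Still open, as far as these compounds go, is whether taking the remaining methoxy groups from compound 4 would give a step like either of the two seen here. Also open, from the compounds shown here alone, is how an amine, a carboxylic acid or a longer chain would compare with methoxy at the place on an aromatic carbon where compound 3 and compound 4 differ.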